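Ethyl homologue of the pyrazole analogue: expected potency

A few compounds are considered here, and "the series" means these few. Any claim that something is new, unique, unknown or untested is made for them only; others in the source may bear on it.

Measured compounds, all in a functional assay on HCT-116 cells (Homo sapiens) for inhibition; on this read-out higher numbers stand for weaker inhibition and lower numbers for stronger inhibition:
compound 1, `CCNCc1cc(-c2c(C(=O)NCC)noc2-c2cc(C(C)C)c(O)cc2O)on1`: compound 1 gives 45 nM
compound 2, `CCNC(=O)c1noc(-c2cc(C(C)C)c(O)cc2O)c1-c1cc(CNC(C)C)no1`: compound 2 gives 109 nM
compound 3, `CCNC(=O)c1noc(-c2cc(C(C)C)c(O)cc2O)c1-c1cnn(C)c1`: compound 3 gives 41 nM

Compound 4, `CCNC(=O)c1noc(-c2cc(C(C)C)c(O)cc2O)c1-c1cnn(CC)c1`, is not yet measured. It differs from compound 3 by methyl in place of hydrogen on a saturated chain carbon bound to an aromatic nitrogen. The same kind of change, (methyl in place of hydrogen on a saturated chain carbon bound to an amine nitrogen and a saturated chain carbon), is found between compound 1 and compound 2, where it gave a 2.4-fold higher number from compound 1 to compound 2 (0.38 log units; beyond the scatter). The place is not the same: in the measured pair the carbon is bound to an amine nitrogen and a saturated chain carbon, in the new pair to an aromatic nitrogen. The two cores differ by 1-methyl-1H-pyrazol-4-yl in place of 3-((ethylamino)methyl)-1,2-oxazol-5-yl on an aromatic carbon, with a 1.1-fold lower number from compound 1 to compound 3 (0.04 log units; within the scatter).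

For compound 3 to compound 4 a step of a 1.5-fold higher number from compound 3 to compound 4 (0.17 log units; within the scatter) is expected, resting on a 2.4-fold higher number from compound 1 to compound 2 (0.38 log units; beyond the scatter) but held smaller given the different place. Compound 4 is therefore estimated at 60 nM, between 25 nM and 150 nM.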

Compound 4, half-maximal inhibitory concentration: 26 nM
Beside the measured number, compound 4's estimate is 2.3-fold (0.36 log units) above it; low and high end bracket the measured number.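

In this assay, the same hydrogen-to-methyl change does not carry over as one step from one core to the other: the same change on two cores in this assay, a 2.4-fold higher number (0.38 log units; beyond the scatter) from compound 1 to compound 2 and a 1.6-fold lower number (0.20 log units; within the scatter) from compound 3 to compound 4, 3.8-fold (0.58 log units) apart, beyond the scatter of two such steps
On the saturated chain carbon bound to an aromatic nitrogen, the change gives a 1.6-fold lower number from compound 3 to compound 4 (0.20 log units; within the scatter), so the penalty seen on the amine side chain does not transfer, while the ring exchanges give a 4.2-fold lower number from compound 2 to compound 4 (0.62 log units; beyond the scatter) and a 1.7-fold lower number from compound 1 to compound 4 (0.24 log units; within the scatter). Going by these compounds alone, with only one pair for each place, this does not separate an effect of the place from an effect of the core, and it sets no rule for the series.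

Going by these compounds, it remains open whether a propyl chain or a chain ending in an amine in place of the ethyl of the 1-ethyl-1H-pyrazol-4-yl group would keep this level of inhibition.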